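Urea aryl variation on the shared core

This account rests on a few compounds, and the source may have more. Where it says the series, first, only, none or still open, it means among the compounds named here.

Among the measured compounds shown here, the three measured members share the core of compound 2 `O=C(Nc1cccc(CNc2nccnc2Cl)c1)Nc1ccccc1Cl` and differ only in the aryl group on the urea. In a functional assay on MGC-803 cells (Homo sapiens) for antiproliferative activity, read by MTT assay, with a stated time of 48 h (on this read-out higher numbers stand for weaker inhibition and lower numbers for stronger inhibition), compound 2 gives 7130 nM, the lowest of the three numbers. Compound 3 `O=C(Nc1ccccc1)Nc1cccc(CNc2nccnc2Cl)c1` gives 16300 nM, and compound 1 `O=C(Nc1cccc(CNc2nccnc2Cl)c1)Nc1cccc2ccccc12` gives 32700 nM; the gap from compound 2 to compound 1 is the widest in the set. For the measured compounds named here, the only single-point step available is a 2.3-fold higher number from compound 2 to compound 3 (0.36 log units; beyond the scatter), so taking the chloro away moves the number up by a margin beyond the scatter.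

Compound 4 `Cc1ccc(NC(=O)Nc2cccc(CNc3nccnc3Cl)c2)cc1Cl` is the next member: 3-chloro-4-methylphenyl in place of 2-chlorophenyl on an amide-type nitrogen. Going by the values given here, no measured pair isolates this change. The chloro is retained but no longer sits where it did in compound 2, and a methyl is added; neither part of the change is tested anywhere in the set. The step to compound 3 bears on it only in showing that the chloro of compound 2 mattered. The expectation is therefore a modest move toward a higher number, a 1.5-fold higher number from compound 2 to compound 4 (0.19 log units; within the scatter), carried with wide uncertainty. Compound 4 is estimated at 11000 nM, with a range from 4000 nM to 30000 nM.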

Compound 4, half-maximal inhibitory concentration: 17500 nM
Beside the measured number, compound 4's estimate is 1.6-fold (0.20 log units) below it; the range from low to high includes it.
By their numbers in this assay, from the lowest: compound 2; then compounds 3, 4 and 1 (each within the scatter of the next).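

Among the compounds shown here, compound 2 to compound 4 is the first step that keeps a chloro on the urea aryl group while changing the group itself. In this assay, the swap to 3-chloro-4-methylphenyl on an amide-type nitrogen gives a 2.5-fold higher number from compound 2 to compound 4 (0.39 log units; beyond the scatter), so the number of compound 2 does not survive this change even though a chloro is still present. Against the plain phenyl, the same group gives a 1.1-fold higher number from compound 3 to compound 4 (0.03 log units; within the scatter) and no difference can be read, which ties the lower number in this small set to 2-chlorophenyl specifically and not to the presence of a chloro on the aryl group; nothing available explains this result.

The compounds shown leave open whether the step to compound 4 follows from the changed chloro placement, the added methyl or both, which 3-chlorophenyl and 4-methylphenyl members would help separate. Also open, from the compounds shown here alone, is whether the 2-chloro can be replaced at all, for instance by 2-fluorophenyl or 2-methoxyphenyl, and how a carboxylic acid or an amine on this aryl group would read.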